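From 4-fluorophenyl to 3,4-dichlorophenyl on sulfur

The source may hold more compounds than are shown below. What is called first, only, known or untested is meant among the compounds shown, and "the series" means these compounds.

Working notes on a functional assay on SF-295 cells (Homo sapiens) for inhibition, read by sulforhodamine B assay, with a stated time of 48 h (on this read-out lower numbers stand for stronger inhibition of growth and higher numbers for weaker inhibition of growth), for this set. Compound 1 `CCOC(=O)[C@H](CCC(=O)O)NC(=O)c1ccc(Sc2nc3cc(N)cc(N)c3nc2-c2ccccc2)cc1` returns only a limit in this assay, < 100000 nM. Compound 2 `Nc1cc(N)c2nc(-c3ccccc3)c(Sc3ccc(F)cc3)nc2c1` gives 30200 nM, the higher of the two numbers; the nearest is compound 3 `COc1cc(CNc2nc3cc(N)cc(N)c3nc2-c2ccccc2)cc(OC)c1OC`, which gives 5620 nM, a gap that lies beyond the scatter. Compound 4 `Nc1cc(N)c2nc(-c3ccccc3)c(Sc3ccc(Cl)c(Cl)c3)nc2c1` is not yet measured; it differs from compound 2 by 3,4-dichlorophenyl in place of 4-fluorophenyl on a sulfur. Within the data shown here, no measured step of this kind exists in the set, so the expected step of a 1.5-fold lower number from compound 2 to compound 4 (0.18 log units; within the scatter) is a small one, likely within the scatter, with direction uncertain. Compound 4 is thus estimated at 20000 nM in this assay, within a range of 6000 nM to 70000 nM.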

Compound 4, concentration for total growth inhibition: 60300 nM
Estimate against measurement, compound 4: 3.0-fold (0.48 log units) below, within the range that was stated.
By their numbers in this assay, from the lowest: compound 3; then compounds 2 and 4 (each within the scatter of the next).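

In this assay, 3,4-dichlorophenyl in place of 4-fluorophenyl on a sulfur gives a 2.0-fold higher number from compound 2 to compound 4 (0.30 log units; within the scatter). This first step at the position does not separate the two groups, so going from one fluorine to two chlorine leaves the reading unresolved. Values of this size lie in the upper reach of this series: the limit of < 100000 nM in this assay, at which 1 of the 4 values shown sits.

As far as these compounds go, whether 4-chlorophenyl or a hexyl chain on the sulfur would stand apart from these two groups remains open. A single step sets no trend for this position.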